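The source may report more compounds than this note shows. Statements on the series, on what has been measured and on what is new or still open speak of the compounds shown alone.

Compound 1 `O=C1C=C(N2CCN(c3ccc(F)cc3)CC2)C(=O)c2ccccc21` gives 11700 nM in a functional assay on DU-145 cells (Homo sapiens) for inhibition, read by MTT assay, with a stated time of 72 h (on this read-out lower numbers stand for stronger inhibition and higher numbers for weaker inhibition), and stands as the higher of the two plain numbers shown. Compound 3 `O=C1C=C(N2CCN(c3cccc(Cl)c3)CC2)C(=O)c2ccccc21` gives 8300 nM in this assay, and the step of a 1.4-fold lower number from compound 1 to compound 3 (0.15 log units; within the scatter) stays within the scatter. Compound 2 `O=C1C=C(N2CCN(c3ccc(Br)cc3)CC2)C(=O)c2ccccc21` reaches only a limit, > 50000 nM, in this assay. Compound 4 `O=C1C=C(N2CCN(c3ccccc3Cl)CC2)C(=O)c2ccccc21` differs from compound 1 by 2-chlorophenyl in place of 4-fluorophenyl on an amine nitrogen in a ring. Among the compounds with values here, two measured steps bear on this change: a 1.4-fold lower number from compound 1 to compound 3 (0.15 log units; within the scatter), where 3-chlorophenyl replaced 4-fluorophenyl with little effect, and an at least 4.2-fold higher number from compound 1 to compound 2 (0.63 log units; beyond the scatter), where bromo in place of fluoro weakened inhibition. Here chlorine, not bromine, enters, so compound 4 is expected to show a 1.0-fold higher number from compound 1 to compound 4 (0.01 log units; within the scatter), nothing beyond the scatter. Compound 4 is therefore estimated at 12000 nM, ranging from 4000 nM to 40000 nM.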

Compound 4, half-maximal inhibitory concentration: 2900 nM
Beside the measured number, compound 4's estimate is 4.1-fold (0.62 log units) above it, outside the stated range (below it).
By their numbers in this assay, from the lowest: compound 4; then compounds 3 and 1 (each within the scatter of the next). At a limit, above all of these: compound 2.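

Within the data shown here, the 2-chlorophenyl group is the first replacement on this ring nitrogen to strengthen inhibition beyond the scatter in this assay, with a 4.0-fold lower number from compound 1 to compound 4 (0.61 log units; beyond the scatter). The 2-chlorophenyl and 3-chlorophenyl groups are also not interchangeable, with a 2.9-fold lower number from compound 3 to compound 4 (0.46 log units; beyond the scatter), so the place of the chlorine on the phenyl ring matters here. The largest step, an at least 17-fold lower number from compound 2 to compound 4 (1.23 log units; beyond the scatter), starts from a limit: the limit of > 50000 nM in this assay, at which 1 of the 4 values shown sits.

The compounds shown leave open whether 2-fluorophenyl, 2-bromophenyl or 2-methoxyphenyl groups would match compound 4, and how a 4-chlorophenyl group would compare.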